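Thiourea series: cytotoxicity on Vero cells, compound 4 outlook

A few compounds are considered here, and "the series" means these few. Any claim that something is new, unique, unknown or untested is made for them only; others in the source may bear on it.

Measured so far in an ADME assay on Vero 76 cells (Chlorocebus sabaeus) for cytotoxicity, read by crystal violet staining, with a stated time of 96 h; on this read-out higher numbers stand for lower toxicity in this test and lower numbers for higher toxicity in this test:
- compound 1 `CC[C@H]1CC[C@H](c2ccc(NC(=S)Nc3cccc(C(F)(F)F)c3)cc2)CC1` gives 10000 nM
- compound 2 `FC(F)(F)c1cccc(NC(=S)Nc2ccc(Cl)cc2)c1` gives 11000 nM
- compound 3 `CCCC[C@H]1CC[C@H](c2ccc(NC(=S)Nc3cccc(C(F)(F)F)c3)cc2)CC1` gives 17000 nM

All three numbers sit close together. Compound 2 holds the second highest of the three in this assay: the nearest is compound 1, with a 1.1-fold higher number from compound 1 to compound 2 (0.04 log units; within the scatter), and the furthest is compound 3, with a 1.5-fold higher number from compound 2 to compound 3 (0.19 log units; within the scatter). The remaining pair, compound 1 against compound 3, shows a 1.7-fold higher number from compound 1 to compound 3 (0.23 log units; within the scatter). Every step in the set is therefore inside the scatter, and nothing in the measured range separates the three compounds.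

Compound 4 `Fc1cccc(NC(=S)Nc2cccc(C(F)(F)F)c2)c1` is not yet measured. Relative to compound 2 the change is 3-fluorophenyl in place of 4-chlorophenyl on an amide-type nitrogen. The measured steps all concern what sits on an aromatic carbon of the other ring: a 1.1-fold higher number from compound 1 to compound 2 (0.04 log units; within the scatter) and a 1.5-fold higher number from compound 2 to compound 3 (0.19 log units; within the scatter) exchange chloro for a substituted cyclohexyl and back, and neither moved the number beyond the scatter. Among the compounds with values here, no measured step exchanges one halogen-bearing phenyl for another on the amide-type nitrogen, so the closest guide is the flatness of the whole set. On that basis no step beyond the scatter is expected for this assay, and the step from compound 2 is estimated as no change at the digits printed from compound 2 to compound 4 (within the scatter). Compound 4 is expected to give about 11000 nM, with a range of 5000 nM to 25000 nM.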

Compound 4, half-maximal cytotoxic concentration: 20000 nM
Compound 4: the middle estimate sits 1.8-fold (0.26 log units) below what was measured, within the range that was stated.
By their numbers in this assay, from the lowest: compounds 1, 2, 3 and 4 (each within the scatter of the next).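

In this assay, the exchange of 4-chlorophenyl for 3-fluorophenyl on an amide-type nitrogen gives a 1.8-fold higher number from compound 2 to compound 4 (0.26 log units; within the scatter) and so stays inside the scatter. Within the data shown here, this extends the flat picture from the aromatic-carbon exchanges of the earlier compounds to a second place, although a single step at this place cannot define its tolerance. The halogen and its printed ring position change together in this step, so their separate contributions cannot be read, and no supporting data bear on the result.

The compounds shown leave open whether any group on this nitrogen can move the number beyond the scatter, for example a phenyl carrying an amine or a carboxylic acid, or a longer chain in place of the phenyl. They also leave open whether replacing the thiocarbonyl with a carbonyl, or replacing the trifluoromethyl group shared by all four compounds, would separate any compound from this tight cluster in this assay.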